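Triazolyl for Trifluoromethyl: Expected Microsomal Half-Life of Compound 4

The compounds below may be only part of what the source reports. "The series", "measured", "known", "first", "only" and "open" are said of these compounds alone.

Compound 1 `COc1ccc(-c2cc(-c3ccc(S(=O)(=O)NC4CC4)cc3)cnc2N)cn1`: 1.9 h
Compound 2 `COc1ccc(-c2cc(-c3ccc(NS(C)(=O)=O)cc3)cnc2N)cn1`: > 4.16 h
Compound 3 `COc1ccc(-c2cc(-c3ccc(C(F)(F)F)cc3)cnc2N)cn1`: 4.75 h

In an in vitro ADME assay on microsomes from liver (Homo sapiens) for metabolic stability (a higher number here means that the compound lasts longer, a lower number that the compound disappears faster), compound 1 gives 1.9 h and compound 3 gives 4.75 h. For compound 2 the result in this assay is a limit of the assay, > 4.16 h. Compound 3 thus holds the highest plain number, with compound 1 nearest: a 2.5-fold higher number from compound 1 to compound 3 (0.40 log units; beyond the scatter). The other readable step is an at least 2.1-fold higher number from compound 1 to compound 2 (0.34 log units; beyond the scatter), while a step that the limit leaves unreadable from compound 2 to compound 3.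

Compound 4 `COc1ccc(-c2cc(-c3ccc(-n4cncn4)cc3)cnc2N)cn1` differs from compound 3 in one place: 1H-1,2,4-triazol-1-yl in place of trifluoromethyl on an aromatic carbon. Both measured steps replace cyclopropylsulfamoyl at this same position and raise the number, but none exchanges trifluoromethyl for a triazolyl, so they give no direct guide. Compound 4 is therefore expected to show no step beyond the scatter, a 1.4-fold lower number from compound 3 to compound 4 (0.13 log units; within the scatter). The estimated value of compound 4 is 3.5 h, ranging from 1.5 h to 6 h.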

Compound 4, half-life: 3.5 h
Estimate against measurement, compound 4: no gap at the digits printed; measured number inside the range.
By their numbers in this assay, from the lowest: compounds 1, 4 and 3 (each within the scatter of the next, the first and the last beyond it).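

In this assay, among these compounds, the earlier compounds did not show how a five-membered aromatic ring at this position compares with trifluoromethyl; the swap gives a 1.4-fold lower number from compound 3 to compound 4 (0.13 log units; within the scatter). The comparison with cyclopropylsulfamoyl gives a 1.8-fold higher number from compound 1 to compound 4 (0.27 log units; within the scatter), so compound 4 is not separated from compound 1 beyond the scatter, unlike compound 3. The comparison with methanesulfonamido, an at least 1.1-fold lower number from compound 2 to compound 4 (0.07 log units; that floor lies within the scatter), gives only a floor, since the value of compound 2 is a limit: the limit of > 4.16 h in this assay, at which 1 of the 4 values shown sits.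

The compounds shown leave open how an amine or a carboxylic acid at this position would compare. They also leave open whether a triazolyl attached through a different ring atom would give a similar half-life.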